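Pyrazin-2-yl in Place of Pyrimidin-2-yl

The source may hold more compounds than are shown below. What is called first, only, known or untested is meant among the compounds shown, and "the series" means these compounds.

Values measured so far in a physicochemical assay for lipophilicity, measured as octanol-water partition (on this read-out higher numbers stand for higher lipophilicity and lower numbers for lower lipophilicity), are these:
- compound 1 `C[C@H](NC(=O)COc1cc(C(F)(F)F)c2c(-c3ccccn3)nn(C)c2n1)c1ccccc1` with 3.5
- compound 2 `Cc1ccc([C@H](C)NC(=O)COc2cc(C)c3c(-c4ncccn4)nn(C)c3n2)cc1` with 3.3

In this assay, for the measured compounds named here, compound 2 gives 3.3 and so stands within the scatter of compound 1 (3.5), the only other compound measured.

Compound 3 `Cc1ccc([C@H](C)NC(=O)COc2cc(C)c3c(-c4cnccn4)nn(C)c3n2)cc1` has not yet been measured. It differs from compound 2 in one place, with the same atoms joined differently pyrazin-2-yl in place of pyrimidin-2-yl on an aromatic carbon and pyrazin-2-yl in place of pyrimidin-2-yl on an aromatic carbon.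

Going by the values given here, no measured pair shows this change, so the data offer no direct guide to its size. The two groups match in everything counted, and the value of compound 2 (3.3) is the only anchor for the expectation. No step beyond the scatter is therefore expected in this assay, only a slight upward drift at most. The estimated step is a number 0.10 log units higher from compound 2 to compound 3 (within the scatter) and it is expected to stay within the scatter. For compound 3 the estimated value is 3.4 (expected range 3 to 3.7) when its measurement is made.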

Compound 3, partition coefficient: 3.9
Beside the measured number, compound 3's estimate is 0.50 log units below it; the whole stated range lies below it.
By their numbers in this assay, from the lowest: compounds 2 and 1 (each within the scatter of the next); then compound 3.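

In this assay, for the compounds shown here, pyrazin-2-yl in place of pyrimidin-2-yl on this aromatic carbon gives a number 0.60 log units higher from compound 2 to compound 3 (beyond the scatter) and so provides the first single-place step, something compounds 1 and 2 could not offer because they differ in more than one place. The two groups have the same heavy atoms, the same single six-membered aromatic ring and the same counts of hydrogen-bond donors and acceptors, so these counts alone do not separate compound 2 from compound 3, even though the read-out does. No measurement at hand accounts for the size or direction of this step.

This single pair leaves open whether the same change would give a similar step on a different background, such as one carrying the trifluoromethyl group and the unsubstituted phenyl ring of compound 1. It also leaves open where other groups at this position would fall on the same read-out, for example pyridazin-3-yl, which is a further six-membered aromatic ring with two nitrogen atoms, or a simple phenyl ring.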